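This account rests on a few compounds, and the source may have more. Where it says the series, first, only, none or still open, it means among the compounds named here.

Compound 1 `COc1ccc(C(Nc2ncnc3c2ncn3[C@@H]2O[C@H](CO[Si](C)(C)C(C)(C)C)[C@]3(OS(=O)(=O)C=C3N)[C@H]2O[Si](C)(C)C(C)(C)C)(c2ccccc2)c2ccccc2)cc1` gives 191000 nM in a functional assay on MT4 cells (Homo sapiens) for cytotoxicity; on this read-out higher numbers stand for lower toxicity in this test and lower numbers for higher toxicity in this test.
Compound 2 `CC(C)(C)[Si](C)(C)OC[C@H]1O[C@@H](n2cnc3ncn([C@@H]4O[C@H](CO[Si](C)(C)C(C)(C)C)[C@@]5(OS(=O)(=O)C=C5N)[C@H]4O[Si](C)(C)C(C)(C)C)c3c2=O)[C@H](O[Si](C)(C)C(C)(C)C)[C@]12OS(=O)(=O)C=C2N` gives only a limit, > 150000 nM, in this assay.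
Compound 3 `CC(C)(C)[Si](C)(C)OC[C@H]1O[C@@H](n2cnc3ncnc(O)c32)[C@H](O[Si](C)(C)C(C)(C)C)[C@]12OS(=O)(=O)C=C2N` gives 15000 nM in this assay.

Among the two numbers shown, compound 3 stands lowest; compound 1 sits higher, beyond the usual scatter (the limit of > 150000 nM in this assay, at which 1 of the 3 values shown sits). Compound 4 `CC(C)(C)[Si](C)(C)OC[C@H]1O[C@@H](n2cnc3ccccc32)[C@H](O[Si](C)(C)C(C)(C)C)[C@]12OS(=O)(=O)C=C2N` differs from compound 3 in one place: a group of 9 heavy atoms (7 carbon, 2 nitrogen; one five-membered aromatic ring with 2 hetero atoms, one six-membered aromatic ring of carbon only) in place of a group of 10 heavy atoms (5 carbon, 4 nitrogen, 1 oxygen; one five-membered aromatic ring with 2 hetero atoms, one six-membered aromatic ring with 2 hetero atoms), on a saturated ring carbon. For the measured compounds named here, no step between measured compounds covers such a change, so no measured reference exists for its size. He expects the step of no change at the digits printed from compound 3 to compound 4 (within the scatter) to stay within the scatter, with no clear direction. For compound 4 he therefore estimates 15000 nM in this assay, with a range from 5000 nM to 60000 nM.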

Compound 4, half-maximal cytotoxic concentration: 15000 nM
Estimate against measurement, compound 4: no gap at the digits printed; measured number inside the range.
By their numbers in this assay, from the lowest: compounds 3 and 4 (each within the scatter of the next); then compound 1.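

In this assay, replacing the leaving group with 1H-benzimidazol-1-yl, which has no hydrogen-bond donor and fewer hydrogen-bond acceptors, gives no change at the digits printed from compound 3 to compound 4 (within the scatter). This is the first pair shown that differs in one place, and it shows that this change on a saturated ring carbon, next to the ring oxygen, leaves the read-out within the scatter. Nothing measured here gives a cause for this result.

Going by these compounds, what an amine or a carboxylic acid on the 1H-benzimidazol-1-yl group would do to this read-out stays open. So does the effect of a simple alkyl chain at the same position.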